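From 2-ethoxyethyl to methyl on a shared core

The source may report more compounds than this note shows. Statements on the series, on what has been measured and on what is new or still open speak of the compounds shown alone.

Compound 1 `CCCn1c(=O)n(CCN(C)C)c(=O)c2[nH]cnc21`: 2700 nM
Compound 2 `CCCn1c(=O)n(CCCO)c(=O)c2[nH]cnc21`: 5100 nM
Compound 3 `CCCn1c(=O)n(CCOCC)c(=O)c2[nH]cnc21`: 70 nM

All three values come from a functional assay (trachea) with Cavia porcellus as the target; a higher number here means that more compound is needed for the effect, a lower number that less compound is needed. Compound 3 has the lowest number of the three, as shown by a 39-fold lower number from compound 1 to compound 3 (1.59 log units; beyond the scatter) and a 73-fold lower number from compound 2 to compound 3 (1.86 log units; beyond the scatter). Both steps are large and beyond the scatter. The other two compounds do not separate, with a 1.9-fold higher number from compound 1 to compound 2 (0.28 log units; within the scatter).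

Compound 4 `CCCn1c(=O)n(C)c(=O)c2[nH]cnc21` keeps the shared core and differs from compound 3 by hydrogen in place of ethoxymethyl on a saturated chain carbon bound to an aromatic nitrogen. This places hydrogen in place of ethoxymethyl on a saturated chain carbon bound to an aromatic nitrogen, so 2-ethoxyethyl becomes methyl. Among the compounds with values here, no measured step removes this chain outright, so the evidence is indirect. The nearest evidence is that compound 3 lies well under both compounds with another chain end, by a 39-fold lower number from compound 1 to compound 3 (1.59 log units; beyond the scatter) and a 73-fold lower number from compound 2 to compound 3 (1.86 log units; beyond the scatter). A large move to a higher number is therefore expected, perhaps somewhat smaller than those two steps. The expected change is a 13-fold higher number from compound 3 to compound 4 (1.11 log units; beyond the scatter). For compound 4 the estimate is 900 nM, with an expected range of 120 nM to 6000 nM.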

Compound 4, half-maximal effective concentration: 1600 nM
Compound 4: the middle estimate sits 1.8-fold (0.25 log units) below what was measured, within the range that was stated.
By their numbers in this assay, from the lowest: compound 3; then compounds 4, 1 and 2 (each within the scatter of the next, the first and the last beyond it).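

Cutting the 2-ethoxyethyl chain back to methyl gives a 23-fold higher number from compound 3 to compound 4 (1.36 log units; beyond the scatter) in this assay, so the low number of compound 3 goes with the ethoxymethyl group on a saturated chain carbon bound to an aromatic nitrogen, and plain methyl does not reach it. The other two chains offer no such advantage over methyl: hydrogen in place of (dimethylamino)methyl gives a 1.7-fold lower number from compound 1 to compound 4 (0.23 log units; within the scatter) and thus no separation, while hydrogen in place of 2-hydroxyethyl gives a 3.2-fold lower number from compound 2 to compound 4 (0.50 log units; beyond the scatter) as a modest step. Among these four compounds, then, a chain beats methyl only with the ethoxy end, and compounds 1 and 2 go against any rule that a longer chain alone lowers the number.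

Nothing shown explains why the ethoxy end stands apart. On these data alone, it also remains open whether a methoxy or propoxy end, or a carboxylic acid, would behave like the ethoxy end.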